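Bromo to Methyl: A Step Expected to Stay Weak

The compounds below may be only part of what the source reports. "The series", "measured", "known", "first", "only" and "open" are said of these compounds alone.

Measured so far:
compound 1 `S=C(N/N=C/c1ccc2ccccc2n1)Nc1ccc(Br)cc1` — 69400 nM
compound 2 `Cc1ccc(NC(=O)N/N=C/c2ccc3ccccc3n2)cc1` — > 100000 nM

Going by the values given here, in a functional assay on SGC-7901 cells (Homo sapiens) for antiproliferative activity, read by sulforhodamine B assay, with a stated time of 72 h (a lower number here means a stronger inhibitor, a higher number a weaker inhibitor), compound 1 gives 69400 nM, the only actual number here. Compound 2 sits at the limit of > 100000 nM in this assay, at which 1 of the 2 values shown sits, which is a limit of the assay, not a number. Compound 3 `Cc1ccc(NC(=S)N/N=C/c2ccc3ccccc3n2)cc1` has not been measured. It differs from compound 1 by methyl in place of bromo on an aromatic carbon. Among the compounds with values here, no step between measured compounds is known, so the change has no measured size; in this assay it is expected to be small, within the scatter or slightly weakening. Compound 3 is estimated at 100000 nM, between 30000 nM and 300000 nM, an expected step of a 1.4-fold higher number from compound 1 to compound 3 (0.16 log units; within the scatter).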

Compound 3, half-maximal inhibitory concentration: 92900 nM
Beside the measured number, compound 3's estimate is 1.1-fold (0.03 log units) above it; low and high end bracket the measured number.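

Going by these compounds alone, replacing 4-bromophenyl with 4-methylphenyl gives the first measured step at this position in this assay (a 1.3-fold higher number from compound 1 to compound 3 (0.13 log units; within the scatter)). Compound 1 and compound 3 therefore cannot be told apart here, and neither bromo nor methyl at this position gives a strong inhibitor. Compound 2 has a limit of the assay rather than a number, so its step to compound 3 cannot be read: the limit of > 100000 nM in this assay, at which 1 of the 3 values shown sits.

As far as these compounds go, whether an amine or a carboxylic acid at this position would shift the number beyond the scatter remains open.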